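Urea aryl swap on a pyrazole series in UO-31 cells

This account rests on a few compounds, and the source may have more. Where it says the series, first, only, none or still open, it means among the compounds named here.

Measured compounds:
compound 1, `COc1cc(Cl)cc(-c2nn(-c3cccc(NC(=O)Nc4cc(C(F)(F)F)cc(C(F)(F)F)c4)c3)cc2-c2ccncc2)c1`, 15%
compound 2, `COc1cc(Cl)cc(-c2nn(-c3cccc(NC(=O)Nc4ccc(Cl)c(Cl)c4)c3)cc2-c2ccncc2)c1`, 88%

In a functional assay on UO-31 cells (Homo sapiens) for inhibition, read by sulforhodamine B assay, with a stated time of 48 h, tested at 1 uM (on this read-out higher numbers stand for a weaker effect at the one concentration tested and lower numbers for a stronger effect), compound 2 gives 88%, the highest of the two numbers shown, and compound 1 gives 15%, a number a long way lower and well beyond the scatter. No step between measured compounds that differ in one place is shown, so the two values can only be set side by side. Compound 3, `COc1cc(Cl)cc(-c2nn(-c3cccc(NC(=O)Nc4cccc(C(F)(F)F)c4)c3)cc2-c2ccncc2)c1`, has not yet been measured in this assay. It differs from compound 2 by 3-(trifluoromethyl)phenyl in place of 3,4-dichlorophenyl on an amide-type nitrogen. Compound 3 is expected to fall between the two measured compounds, with a step of a number 38 percentage points lower from compound 2 to compound 3 (beyond the scatter) expected downward and beyond the scatter, because compound 1 gives 15% with a related group on the same amide-type nitrogen. The estimate for compound 3 in this assay is 50%, within a range from 15% to 88%.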

Compound 3, a percentage reported as activity, at one concentration (the size of the read-out at that concentration, not a potency): 51%
Beside the measured number, compound 3's estimate is 1 percentage points below it, within the range that was stated.
By their numbers in this assay, from the lowest: compound 1; then compound 3; then compound 2.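

In this assay, within the data shown here, putting 3-(trifluoromethyl)phenyl in place of 3,4-dichlorophenyl on the amide-type nitrogen gives a number 37 percentage points lower from compound 2 to compound 3 (beyond the scatter), which is a stronger effect at the one concentration tested and the first reading of this position through a change in one place. Hydrogen in place of trifluoromethyl on an aromatic carbon gives a number 36 percentage points higher from compound 1 to compound 3 (beyond the scatter), a weaker effect, so removing this one trifluoromethyl group from the aryl ring on that nitrogen is enough to shift the read-out by a large step. Nothing available explains why either change has the effect it does.

The compounds shown leave open how a nitrile or a methoxy group would read in place of that trifluoromethyl. They also leave open whether a single chlorine on the same ring would read closer to compound 2 or to compound 3.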